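The compounds below may be only part of what the source reports. "The series", "measured", "known", "first", "only" and "open" are said of these compounds alone.

Two members of one family of folate-like molecules have been tested in a functional assay on CCRF-CEM cells (Homo sapiens) for inhibition; a lower number here means a stronger inhibitor, a higher number a weaker inhibitor. Compound 1, with the structure `CCOC(=O)CC[C@H](NC(=O)[C@H](CCC(=O)O)NC(=O)c1ccc(N(C)Cc2cnc3nc(N)nc(N)c3n2)cc1)C(=O)OCC`, gives 10 ug/mL. Compound 2, with the structure `CCOC(=O)CC[C@H](NC(=O)CC[C@H](NC(=O)c1ccc(N(C)Cc2cnc3nc(N)nc(N)c3n2)cc1)C(=O)N[C@@H](CCC(=O)OCC)C(=O)OCC)C(=O)OCC`, gives 3.8 ug/mL. Of these two numbers, compound 1 has the higher one, and the gap between compound 1 and compound 2 lies beyond the usual scatter of such measurements, so compound 2 is the stronger inhibitor of the pair.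

The next compound, compound 3, has the structure `CCOC(=O)CC[C@H](NC(=O)c1ccc(N(C)Cc2cnc3nc(N)nc(N)c3n2)cc1)C(=O)N[C@@H](CCC(=O)OCC)C(=O)OCC` and has not yet been tested in this assay. The difference between compound 1 and compound 3 is small and is counted as ethyl in place of hydrogen on an oxygen next to a carbonyl group. Among the measured compounds shown here, no measured pair in this set shows the effect of exactly this change, so the expectation must rest on the single measured step and on the modest size of the change.

Compound 3 is expected to give a number close to that of compound 1, and the step of a 1.7-fold lower number from compound 1 to compound 3 (0.22 log units; within the scatter) is estimated to be small, tilted toward a slightly lower number, and possibly within the scatter. The estimate for compound 3 is therefore 6 ug/mL, with a range from 2 ug/mL to 15 ug/mL.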

Compound 3, concentration for 50% inhibition: 0.85 ug/mL
Compound 3: the middle estimate sits 7.1-fold (0.85 log units) above what was measured, outside the stated range (below it).
By their numbers in this assay, from the lowest: compound 3; then compound 2; then compound 1.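

In this assay, putting ethyl in place of hydrogen on an oxygen next to a carbonyl group gives a 12-fold lower number from compound 1 to compound 3 (1.07 log units; beyond the scatter), so this one small change at this position has a large effect on the read-out. The earlier compounds shown here could not show this, as they differ in more than one place and offered no direct reading of any single change. The data available here give no explanation for the size of the step, so it stands as an observation without a known cause.

The compounds shown carry only hydroxy or ethoxy at this position, so it remains open how the number would respond to methoxy, to a longer chain such as butoxy, or to an amine joined to the carbonyl to form an amide. Going by these compounds, this change is also read from a single pair, so whether ethyl in place of hydrogen would give a step of similar size at the other carboxy positions of this family remains unknown.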